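The source may hold more compounds than are shown below. What is called first, only, known or untested is meant among the compounds shown, and "the series" means these compounds.

Working notes on the series. The three measured compounds share one amide core and differ at the two outer groups. In a functional assay for antagonist activity at transient receptor potential cation channel subfamily V member 1 (Rattus norvegicus) (a lower number here means a stronger inhibitor, a higher number a weaker inhibitor), compound 2 `CC(C)(C)c1ccc(NC(=O)c2ccc(-c3ncccc3C#N)cc2)cc1` gives 13 nM, the lowest of the three numbers recorded. Compound 3 `CC(C)(C)c1ccc(NC(=O)c2ccc(-c3ncccc3NS(C)(=O)=O)cc2)cc1` gives 35 nM, and the step of a 2.7-fold higher number from compound 2 to compound 3 (0.43 log units; beyond the scatter) is beyond the scatter but modest. Compound 1 `N#Cc1ccc(NC(=O)c2ccc(-c3ncccc3C(F)(F)F)cc2)cc1` gives 1300 nM; it differs from compound 2 in two places at once, so its gap to compound 2 is only what the two values show and is not read as a single step.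

Compound 4 `CC(C)(C)c1ccc(NC(=O)c2ccc(-c3ncccc3-c3nn[nH]n3)cc2)cc1` has not been measured. It differs from compound 2 as follows: 2H-tetrazol-5-yl in place of cyano on an aromatic carbon. For the measured compounds named here, the only measured step that bears on this position is the one from compound 2 to compound 3, where another group replaced the cyano on the same aromatic carbon, and that replacement moved the number by a modest amount toward a weaker inhibitor. Nothing in the data speaks to a tetrazole directly. On that basis a modest rise in number from compound 2 is expected, of a size comparable to the measured step, rather than no change or a large shift.

For compound 4 the expected value in this assay is 40 nM, with a range from 12 nM to 130 nM. The step this estimate implies, a 3.1-fold higher number from compound 2 to compound 4 (0.49 log units; beyond the scatter), is expected to be modest.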

Compound 4, half-maximal inhibitory concentration: > 4000 nM
Compound 4 was reported as a limit; the forecaster's own chance of this, stated with the estimate: 3%; middle value at least 100-fold (2.00 log units) away from the limit.
By their numbers in this assay, from the lowest: compound 2; then compound 3; then compound 1. At a limit, above all of these: compound 4.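

In this assay compound 4 is reported only as a limit and not as a number: the limit of > 4000 nM in this assay, at which 1 of the 4 values shown sits.

Even so, 2H-tetrazol-5-yl in place of cyano gives an at least 300-fold higher number from compound 2 to compound 4 (2.48 log units; beyond the scatter), and the same group in place of methanesulfonamido gives an at least 110-fold higher number from compound 3 to compound 4 (2.05 log units; beyond the scatter), both of them large. Set against the modest 2.7-fold higher number from compound 2 to compound 3 (0.43 log units; beyond the scatter), this shows that the aromatic carbon ortho to a large group, two atoms from the ring nitrogen, does not accept every replacement of cyano, a limit on this position that compound 2 and compound 3 alone gave no sign of.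

Compound 4 alone cannot separate an effect of the five-membered aromatic ring with 4 hetero atoms from one of the size of the entering group, and a carboxylic acid, a primary amide or a plain phenyl ring on the same carbon would bear on that question. As far as these compounds go, the effect of trifluoromethyl at this carbon also remains open, as compound 1 differs from compound 2 in two places at once.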